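Replacing Chloro with Hydroxy on the Aryl Ring

The source may report more compounds than this note shows. Statements on the series, on what has been measured and on what is new or still open speak of the compounds shown alone.

The study concerns a small series sharing a common core. Compound 1 `Cn1c(SCC(=O)Nn2c(COc3ccc(Cl)cc3Cl)nc3ccccc3c2=O)nc(-c2ccccc2)c(C#N)c1=O` carries a bare phenyl ring at one position; in a functional assay on the whole organism (strain albino) for inhibition, with Rattus norvegicus as the target, read by paw edema, with a stated time of 1 h, at a dose of 100 mg/kg by the oral route (a lower number here means less inhibition, a higher number more inhibition at the dose given (going by the name of the read-out)), compound 1 gives 54.6%. Compound 2 `Cn1c(SCC(=O)Nn2c(COc3ccc(Cl)cc3Cl)nc3ccccc3c2=O)nc(-c2ccc(Cl)cc2)c(C#N)c1=O` differs by a single change, and the step of a number 21.8 percentage points higher from compound 1 to compound 2 (beyond the scatter) was chloro in place of hydrogen on an aromatic carbon. Within the data shown here, on the numbers so far, compound 2 stands highest of the two, with the nearest neighbour compound 1 a modest distance below it; in this assay compound 2 gives 76.4%.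

Compound 3 `Cn1c(SCC(=O)Nn2c(COc3ccc(Cl)cc3Cl)nc3ccccc3c2=O)nc(-c2ccc(O)cc2)c(C#N)c1=O` is the next step. It differs from compound 2 by hydroxy in place of chloro on an aromatic carbon. Among the measured compounds shown here, the only measured step that bears on this position is the one from compound 1 to compound 2, which showed that a chloro group here raised inhibition modestly. For the measured compounds named here, there is no measured step involving a hydroxy group, so the effect of this swap is not directly known. Because the step of a number 21.8 percentage points higher from compound 1 to compound 2 (beyond the scatter) gave a higher number with the chloro in place, the account expects that removing it will lower the inhibition in this assay, likely a modest drop a number 16.4 percentage points lower from compound 2 to compound 3 (beyond the scatter). Compound 3 is therefore estimated to give 60%, within a range from 45% to 78%.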

Compound 3, a percentage reported as inhibition, in the whole organism at one dose (the size of the read-out at that dose, not a potency): 80%
Compound 3: middle estimate off by 20 percentage points, on the low side, and the stated range ends below it.
By their numbers in this assay, from the lowest: compound 1; then compounds 2 and 3 (each within the scatter of the next).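

In this assay, the swap of chloro for hydroxy on this aromatic carbon, para to a large group, comes out as a number 3.6 percentage points higher from compound 2 to compound 3 (within the scatter), so the 4-chlorophenyl and 4-hydroxyphenyl forms cannot be told apart here. Against the bare phenyl ring, hydroxy gives a number 25.4 percentage points higher from compound 1 to compound 3 (beyond the scatter), so the gain first seen with chloro, a number 21.8 percentage points higher from compound 1 to compound 2 (beyond the scatter), is no longer tied to that one group: two substituents that differ in their element and in their count of hydrogen-bond donors both read beyond the scatter relative to hydrogen. Nothing measured here explains why these two groups read alike.

As far as these compounds go, whether other groups at this place, such as an amine, a methoxy group or a carboxylic acid, would also match compound 2 and compound 3 remains open, as does whether either substituent would have the same effect elsewhere on the ring. These readings also come from one oral dose at one stated time, so they leave open how compound 2 and compound 3 would compare at other doses or at later times.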